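Swapping a heptyl chain for an aryl group in a lactam series

The compounds below may be only part of what the source reports. "The series", "measured", "known", "first", "only" and "open" are said of these compounds alone.

Measured compounds:
- compound 1, `COC(=O)N1C[C@H](NC(=O)OCCCCC2CCCCC2)C1=O`, 7180 nM in an assay on HEK293 cells for inhibition of N-acylethanolamine-hydrolyzing acid amidase (Homo sapiens), read by fluorescence, with stated times of 10 min and 50 min; a lower number here means a stronger inhibitor, a higher number a weaker inhibitor
- compound 2, `CON1C[C@@H](NC(=O)OCCCCC2CCCCC2)C1=O`, 56 nM in this assay
- compound 3, `CCCCCCCON1C(=O)[C@@H](NC(=O)OCCCCC2CCCCC2)[C@@H]1C`, 2230 nM in this assay

Among these three numbers, compound 3 stands second highest. Its nearest neighbour is compound 1, whose number is higher by a margin beyond the scatter; compound 2 sits far lower, also beyond the scatter. Compound 4, `C[C@H]1[C@H](NC(=O)OCCCCC2CCCCC2)C(=O)N1Oc1ccc(C(F)(F)F)cc1`, has not yet been measured. It differs from compound 3 in one place: 4-(trifluoromethyl)phenyl in place of heptyl on an oxygen. Among the measured compounds shown here, no measured pair here shows what an aryl group does on that oxygen, so the direction of the step rests on expectation alone. The expected step from compound 3 to compound 4 in this assay is a 2.8-fold lower number from compound 3 to compound 4 (0.45 log units; beyond the scatter), a move toward a lower number, though a change within the scatter cannot be excluded. For compound 4 the estimated value in this assay is 800 nM, with a range from 150 nM to 5000 nM.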

Compound 4, half-maximal inhibitory concentration: 31 nM
Beside the measured number, compound 4's estimate is 26-fold (1.41 log units) above it; measured number outside the range, below it.
By their numbers in this assay, from the lowest: compounds 4 and 2 (each within the scatter of the next); then compound 3; then compound 1.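

Putting 4-(trifluoromethyl)phenyl in place of heptyl on an oxygen, the one bonded to the amide-type nitrogen in the ring, has a large effect in this assay: the result is a 72-fold lower number from compound 3 to compound 4 (1.86 log units; beyond the scatter). Among the compounds shown here, this is the first pair that differs in this one place, and it shows that the group on this oxygen can strongly change how well these compounds inhibit the enzyme, and that a long open chain is not required there. Nothing measured here explains why the step is so large.

From the compounds shown here alone, it remains open whether the gain comes from the aromatic ring itself or from the trifluoromethyl group, a question that plain phenyl on the same oxygen could address. How a benzyl group or a shorter chain such as butyl would compare there is also unknown.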